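The source may report more compounds than this note shows. Statements on the series, on what has been measured and on what is new or still open speak of the compounds shown alone.

Measured in a functional assay on U-87MG ATCC cells for antiproliferative activity against U-87 MG (Homo sapiens), read by spectrophotometry, with a stated time of 2 days; a higher number here means a weaker inhibitor of growth, a lower number a stronger inhibitor of growth:

- Compound 1 `CN(c1cccc2c1CN(c1nc(Nc3cc(C(F)(F)F)cc(C(F)(F)F)c3)ncc1C(F)(F)F)C2)S(C)(=O)=O` gives 16800 nM in this test
- Compound 2 `COc1cc(Nc2ncc(C(F)(F)F)c(N3Cc4cccc(N(C)S(C)(=O)=O)c4C3)n2)cc(OC)c1` gives > 30000 nM in this test

For the measured compounds named here, compound 1 is the only one of the pair with a true number. Compound 2 gives > 30000 nM as a limit of the assay and not a number. Going by the values given here, its exact place on the scale is therefore unknown, and no step between measured compounds can be sized.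

The next compound is compound 3 `COc1cc(Nc2ncc(C(F)(F)F)c(N3Cc4cccc(N(C)S(C)(=O)=O)c4C3)n2)cc(C(F)(F)F)c1`, which has yet to be tested. It carries trifluoromethyl in place of methoxy on an aromatic carbon, so 3,5-dimethoxyphenyl becomes 3-methoxy-5-(trifluoromethyl)phenyl.

Among the compounds with values here, with compound 1 at 16800 nM as the only measured number, a modest move toward stronger inhibition of growth in this assay is expected. Compound 3 may well stay at the limit of the assay seen for compound 2. The expected change is an at least 1.3-fold lower number from compound 2 to compound 3 (0.13 log units; that floor lies within the scatter) and remains a rough estimate. For compound 3 the estimated value is 22000 nM with an expected range from 10000 nM to 30000 nM in this measurement.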

Compound 3, concentration for 50% growth inhibition: > 30000 nM
Compound 3: no number, only a limit (the forecaster's own chance of this, stated with the estimate: 40%); middle value at least 1.3-fold (0.13 log units) away from the limit.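

In this assay compound 3 gives > 30000 nM, which is a limit of the assay and not a number. Compound 3 therefore shows that a single trifluoromethyl, paired with one methoxy on the same ring, gives no readable value here, whereas compound 1, with two trifluoromethyl groups on that ring, gives a true number; putting methoxy in place of trifluoromethyl on an aromatic carbon amounts to an at least 1.7-fold higher number from compound 1 to compound 3 (0.25 log units; that floor lies within the scatter), so the smallest step these values allow does not by itself establish a real loss. The step from compound 2 to compound 3 cannot be read, because both compounds rest on the same limit: the limit of > 30000 nM in this assay, at which 2 of the 3 values shown sit.

From the compounds shown here alone, whether trifluoromethyl in place of methoxy changes growth inhibition at all stays open, since the true positions of compound 2 and compound 3 on the scale are unknown. Also open, going by these compounds, is what a chlorine atom, a nitrile or an amine at this place on the ring would give in this assay.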